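Replacing 4-methoxybenzyl with 3-methylbut-2-en-1-yl

This account rests on a few compounds, and the source may have more. Where it says the series, first, only, none or still open, it means among the compounds named here.

Measured in a functional assay on EOL1 cells (Homo sapiens) for inhibition, read by fluorescence, with a stated time of 72 h; a lower number here means a stronger inhibitor of growth, a higher number a weaker inhibitor of growth:
Compound 1 `CC(C)CCn1cnc2c(Nc3ccc(Cl)cc3)nc(N[C@H]3CC[C@H](N)CC3)nc21`: 90 nM
Compound 2 `COc1ccc(Cn2cnc3c(Nc4cccc(Cl)c4)nc(N[C@H]4CC[C@H](N)CC4)nc32)cc1`: 530 nM

Compound 2 has the higher of the two numbers, beyond the scatter from compound 1. Among the compounds with values here, these two differ in more than one place, so they provide no single-change step. Compound 3 `CC(C)=CCn1cnc2c(Nc3cccc(Cl)c3)nc(N[C@H]3CC[C@H](N)CC3)nc21` differs from compound 2 as follows: 2-methylprop-1-en-1-yl in place of 4-methoxyphenyl on a saturated chain carbon bound to an aromatic nitrogen. The expectation is tentative and leans only on compound 1, at 90 nM, as the lower reference. The expected change in this assay is a 2.7-fold lower number from compound 2 to compound 3 (0.42 log units; beyond the scatter), towards a lower number and modestly beyond the scatter. For compound 3 the estimated value is 200 nM, with an expected range of 70 nM to 550 nM.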

Compound 3, concentration for 50% growth inhibition: 80 nM
Compound 3: middle estimate off by 2.5-fold (0.40 log units), on the high side, within the range that was stated.
By their numbers in this assay, from the lowest: compounds 3 and 1 (each within the scatter of the next); then compound 2.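

In this assay, this first single-change reading at the saturated chain carbon bound to an aromatic nitrogen gives a 6.6-fold lower number from compound 2 to compound 3 (0.82 log units; beyond the scatter) for 2-methylprop-1-en-1-yl in place of 4-methoxyphenyl. The position therefore responds to the group it carries, and in this pair an aromatic ring on the chain is not needed for the lower number. Nothing available explains the step.

The compounds shown do not separate the loss of the ring from the presence of the double bond. From the compounds shown here alone, how a chain ending in an amine or a carboxylic acid would read at this position remains open.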